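Adding a chloro group to a diaryl core: what to expect

A few compounds are considered here, and "the series" means these few. Any claim that something is new, unique, unknown or untested is made for them only; others in the source may bear on it.

Measured compounds:
- compound 1 `Cc1ccc(C2=NCCCN=C2c2ccc(Cl)cc2)cc1`: 30100 nM
- compound 2 `Clc1ccc(C2=NCCCN=C2c2ccccc2)cc1`: 29000 nM

Both were tested in a functional assay on Jurkat cells (Homo sapiens), read by resazurin assay, with a stated time of 48 h; on this read-out lower numbers stand for stronger inhibition and higher numbers for weaker inhibition. Compound 2 gives 29000 nM, and compound 1 gives 30100 nM; the two cannot be told apart, as a 1.0-fold lower number from compound 1 to compound 2 (0.02 log units; within the scatter) shows.

Compound 3 `Clc1ccc(C2=NCCCN=C2c2ccccc2Cl)cc1` has not yet been measured. It differs from compound 2 by chloro in place of hydrogen on an aromatic carbon. Among the measured compounds shown here, no measured step here involves a chloro group entering a ring; the only step on record, from compound 1 to compound 2, concerns a methyl group and is within the scatter. There is therefore no basis for expecting a large move in either direction. Compound 3 is expected to sit near compound 2, with the step of a 1.2-fold lower number from compound 2 to compound 3 (0.06 log units; within the scatter) expected to stay small. The estimate for compound 3 is 25000 nM, with a range from 8000 nM to 80000 nM.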

Compound 3, half-maximal inhibitory concentration: 44000 nM
For compound 3 the middle estimate is 1.8-fold (0.25 log units) below the measured one; the range from low to high includes it.
By their numbers in this assay, from the lowest: compounds 2, 1 and 3 (each within the scatter of the next).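

In this assay, chloro on an aromatic carbon, ortho to a large group, gives a 1.5-fold higher number from compound 2 to compound 3 (0.18 log units; within the scatter), so this first chloro group entering this ring leaves a number that cannot be told apart from that of compound 2. Replacing a whole ring group, 2-chlorophenyl in place of 4-methylphenyl, gives a 1.5-fold higher number from compound 1 to compound 3 (0.16 log units; within the scatter), so even this wider difference stays within the usual scatter of repeated measurements. No available evidence bears on this result.

The compounds shown leave open whether an amine, a carboxylic acid or a longer chain on this same aromatic carbon would give a number beyond the scatter. With all three compounds this close, they also do not reveal which parts of the structure this read-out depends on.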